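Turning a Second Ring Stereocentre the Other Way

This account rests on a few compounds, and the source may have more. Where it says the series, first, only, none or still open, it means among the compounds named here.

Of the compounds shown here, three have been measured in an assay on Sf9 cells for inhibition of histone deacetylase 11 (Homo sapiens), read by fluorescence, tested at 0.5 uM; on this read-out lower numbers stand for less inhibition and higher numbers for more inhibition at the one concentration tested (going by the name of the read-out). Compound 1 `O=C(/C=C/c1cn([C@H]2C[C@@H](CO)N(Cc3ccccc3)C2)nn1)NO` gives 35%, compound 2 `O=C(/C=C/c1cn([C@H]2C[C@H](CO)N(Cc3ccccc3)C2)nn1)NO` gives 20% and compound 3 `O=C(/C=C/c1cn([C@H]2C[C@H](CO)N(CCCc3ccccc3)C2)nn1)NO` gives 16%. Compound 2 thus stands second highest of the three: its step to compound 3 is a number 4 percentage points lower from compound 2 to compound 3 (within the scatter), while a number 15 percentage points lower from compound 1 to compound 2 (beyond the scatter). The new compound 4 `O=C(/C=C/c1cn([C@@H]2C[C@H](CO)N(Cc3ccccc3)C2)nn1)NO` keeps every atom and bond of compound 2 and changes only the drawn configuration: the two compounds have the same atoms and bonds and differ only in configuration as drawn: 1 of 3 stereo elements differ; a stereocentre at a saturated ring carbon is drawn S in compound 2 and R in compound 4. Going by the values given here, the one measured step that bears on this is a number 15 percentage points lower from compound 1 to compound 2 (beyond the scatter), which likewise rested on nothing but configuration, namely (the fact that compounds 1 and 2 differ only in the configuration as drawn). On these data alone, a change of configuration at a ring carbon can therefore move the number modestly, but which way remains open. The expected value for compound 4 is 24%, within a range from 8% to 42%. That would mean an expected step of a number 4 percentage points higher from compound 2 to compound 4 (within the scatter).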

Compound 4, a percentage reported as inhibition, at one concentration (the size of the read-out at that concentration, not a potency): < 10%
Compound 4 was reported as a limit; the forecaster's own chance of this, stated with the estimate: 0%; middle value at least 14 percentage points from the limit.
By their numbers in this assay, from the lowest: compounds 3 and 2 (each within the scatter of the next); then compound 1. At a limit, below all of these: compound 4.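

Turning this second stereocentre at a saturated ring carbon gives a number at least 10 percentage points lower from compound 2 to compound 4 (that floor lies within the scatter), so the drawn R form here does not raise the number, although the floor of that step alone does not clear the scatter. The value of compound 4, < 10%, is a limit of the assay and not a number. With both ring stereocentres changed, the gap is clear: a number at least 25 percentage points lower from compound 1 to compound 4 (beyond the scatter).

On these data alone, how far compound 4 lies under its limit stays open. So does whether an amine or a carboxylic acid in place of the hydroxyl group would keep this dependence on configuration in this assay.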